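Chain shortening and ring closure on an amide of a cytosine nucleoside

This account rests on a few compounds, and the source may have more. Where it says the series, first, only, none or still open, it means among the compounds named here.

Measured compounds:
compound 1, `CCCC(=O)Nc1ccn([C@@H]2CO[C@H](CO)O2)c(=O)n1`, 8070 nM
compound 2, `CCCCCCCCC(=O)Nc1ccn([C@@H]2CO[C@H](CO)O2)c(=O)n1`, 276 nM
compound 3, `CCCCCCCCCCCCCCCCCC(=O)Nc1ccn([C@@H]2CO[C@H](CO)O2)c(=O)n1`, 125 nM

In a functional assay on SW1573 cells (Homo sapiens) for cytotoxicity, read by sulforhodamine B assay, with a stated time of 72 h (a lower number here means a stronger inhibitor, a higher number a weaker inhibitor), compound 2 stands second highest of the three numbers; its nearest neighbour is compound 3 with a 2.2-fold lower number from compound 2 to compound 3 (0.34 log units; beyond the scatter), while compound 1 lies furthest away with a 29-fold lower number from compound 1 to compound 2 (1.47 log units; beyond the scatter). Compound 4, `O=C(Nc1ccn([C@@H]2CO[C@H](CO)O2)c(=O)n1)C1CCCCC1`, differs from compound 2 by cyclohexyl in place of octyl on a carbonyl carbon. The step that bears on this change is a 29-fold lower number from compound 1 to compound 2 (1.47 log units; beyond the scatter), a large step in which a longer chain gave a lower number; the step of a 2.2-fold lower number from compound 2 to compound 3 (0.34 log units; beyond the scatter) was modest. Compound 4 carries fewer chain carbons than compound 2 and closes them into a ring, so a higher number is expected, smaller than the step from compound 1. Compound 4 is therefore estimated at 1500 nM, range 400 nM to 5000 nM, a step of a 5.4-fold higher number from compound 2 to compound 4 (0.74 log units; beyond the scatter).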

Compound 4, half-maximal inhibitory concentration: 14000 nM
Estimate against measurement, compound 4: 9.3-fold (0.97 log units) below; measured number above the stated range.
By their numbers in this assay, from the lowest: compound 3; then compound 2; then compounds 1 and 4 (each within the scatter of the next).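

In this assay, cyclohexyl in place of octyl on the carbonyl carbon gives up nearly all of the gain seen along the straight chains (a 51-fold higher number from compound 2 to compound 4 (1.71 log units; beyond the scatter)). Cyclohexyl in place of propyl at the same carbon makes no difference that can be read (a 1.7-fold higher number from compound 1 to compound 4 (0.24 log units; within the scatter)). So the earlier link between more chain carbons and a lower number does not extend to this ring, and compound 4 goes against it. Going by these compounds, whether a phenyl ring or a branched chain such as 2-ethylhexyl would keep the lower numbers stays open. Nothing available explains why the ring behaves this way.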